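The source may hold more compounds than are shown below. What is called first, only, known or untested is meant among the compounds shown, and "the series" means these compounds.

Measured so far in a physicochemical assay for solubility, with a stated time of 24 h, at pH 4.5; on this read-out higher numbers stand for higher solubility and lower numbers for lower solubility:

- compound 1 `O=C(NC[C@@H]1[C@H]2CN(C(=O)C3CC3c3cc(Cl)cc(Cl)c3)C[C@@H]12)c1ccc2[nH]c(=O)oc2c1`: < 1 ug/mL
- compound 2 `N#Cc1cc(COC(=O)N2C[C@@H]3[C@@H](CNC(=O)c4ccc5[nH]c(=O)oc5c4)[C@@H]3C2)cc(OC(F)(F)F)c1`: < 1 ug/mL

Compound 1 stands at < 1 ug/mL, which is a limit of the assay and not a number. Compound 2 gives the same reading, so the data so far show (the limit of < 1 ug/mL in this assay, at which 2 of the 2 values shown sit). No number is therefore available as a starting point.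

Compound 3 `Cc1cc(COC(=O)N2C[C@@H]3[C@@H](CNC(=O)c4ccc5[nH]c(=O)oc5c4)[C@@H]3C2)no1` differs from compound 1 in one place, on a carbonyl carbon, where (5-methyl-1,2-oxazol-3-yl)methoxy enters: a group of 8 heavy atoms (5 carbon, 1 nitrogen, 2 oxygen; one five-membered aromatic ring with 2 hetero atoms) in place of a group of 11 heavy atoms (9 carbon, 2 chlorine; one three-membered non-aromatic ring of carbon only, one six-membered aromatic ring of carbon only), on a carbonyl carbon. Going by the values given here, no measured step covers a change of this kind, so the expectation rests only on that count, in which chlorine leaves and hydrogen-bond acceptors enter. An upward move beyond the usual scatter is expected in this assay, with an estimated step of an at least 15-fold higher number from compound 1 to compound 3 (1.17 log units; beyond the scatter). For compound 3 the estimated value is 15 ug/mL, with an expected range from 3 ug/mL to 80 ug/mL.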

Compound 3, solubility: > 93 ug/mL
Compound 3 was reported as a limit; the forecaster's own chance of this, stated with the estimate: 15%; at least 6.2-fold (0.79 log units) between middle value and limit.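

In this assay, placing (5-methyl-1,2-oxazol-3-yl)methoxy on this carbonyl carbon, in place of the group in compound 1, gives an at least 93-fold higher number from compound 1 to compound 3 (1.96 log units; beyond the scatter), so a change at this one place can move the read-out far beyond the usual scatter. Going by these compounds alone, the earlier compounds gave only a lower limit, and this is the first reading at the other end of the assay's range: the limit of > 93 ug/mL in this assay, at which 1 of the 3 values shown sits. Compound 2 also carries an oxygen-linked group on this carbonyl carbon and gives < 1 ug/mL, a limit, so that link alone does not go with a high reading.

On these data alone, both ends of the step are limits, so its true size stays open. Also open, as far as these compounds go, is how much depends on the methyl group or the ring, which a plain 1,2-oxazol-3-ylmethoxy or a group carrying an amine could test.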